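Varying the acyl group on a piperazine amide

The compounds below may be only part of what the source reports. "The series", "measured", "known", "first", "only" and "open" are said of these compounds alone.

Measured compounds:
compound 1 `CCCCCC(=O)c1ccc(OCCCN2CCN(C(=O)N3CCOCC3)CC2)cc1` — 17800 nM
compound 2 `CCCCCC(=O)c1ccc(OCCCN2CCN(C(=O)C(C)C)CC2)cc1` — 29500 nM
compound 3 `CCCCCC(=O)c1ccc(OCCCN2CCN(C(=O)C3CCC3)CC2)cc1` — 10200 nM

In an assay on isolated protein for binding affinity to histamine H2 receptor (Homo sapiens) (a higher number here means a weaker inhibitor, a lower number a stronger inhibitor), compound 3 gives the lowest of the three numbers; the step of a 1.7-fold lower number from compound 1 to compound 3 (0.24 log units; within the scatter) stays within the scatter, while the step of a 2.9-fold lower number from compound 2 to compound 3 (0.46 log units; beyond the scatter) is beyond it. Compound 4 `CCCCCC(=O)c1ccc(OCCCN2CCN(C(=O)CSCC)CC2)cc1` carries the change ((ethylsulfanyl)methyl in place of cyclobutyl on a carbonyl carbon). All three measured steps alter the same group on the carbonyl carbon: a 1.7-fold higher number from compound 1 to compound 2 (0.22 log units; within the scatter) and a 1.7-fold lower number from compound 1 to compound 3 (0.24 log units; within the scatter) stayed within the scatter and only a 2.9-fold lower number from compound 2 to compound 3 (0.46 log units; beyond the scatter) was modest. A further swap at this position is therefore expected to move this assay little, with the estimated step of a 1.6-fold higher number from compound 3 to compound 4 (0.20 log units; within the scatter) and no clear direction. Compound 4 is accordingly estimated at 16000 nM, within a range from 5000 nM to 50000 nM.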

Compound 4, inhibition constant: 22900 nM
Compound 4: the middle estimate sits 1.4-fold (0.16 log units) below what was measured; the range from low to high includes it.
By their numbers in this assay, from the lowest: compounds 3, 1, 4 and 2 (each within the scatter of the next, the first and the last beyond it).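

In this assay, replacing the ring of cyclobutyl with the open (ethylsulfanyl)methyl group, of equal heavy-atom count, gives a modest change, a 2.2-fold higher number from compound 3 to compound 4 (0.35 log units; beyond the scatter), so this position does respond to a swap other than the one from isopropyl to cyclobutyl. The other two steps, a 1.3-fold lower number from compound 2 to compound 4 (0.11 log units; within the scatter) and a 1.3-fold higher number from compound 1 to compound 4 (0.11 log units; within the scatter), stay within the scatter, leaving compound 3 apart from compound 2 and compound 4 but not from compound 1. Nothing available accounts for the step from cyclobutyl. The compounds shown leave open whether cyclopentyl or ethoxymethyl on the same carbonyl carbon would track cyclobutyl or (ethylsulfanyl)methyl.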